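A few compounds are considered here, and "the series" means these few. Any claim that something is new, unique, unknown or untested is made for them only; others in the source may bear on it.

Measured compounds:

Compound 1, `COc1ccc(/C=C/[C@H]2CC=CC(=O)O2)cc1`. In a functional assay on HBL-100 cells (Homo sapiens) for antiproliferative activity, read by luminescence and CellTiter-Glo, with a stated time of 48 h (a higher number here means a weaker inhibitor, a lower number a stronger inhibitor), compound 1 gives > 100000 nM, which is a limit of the assay rather than a number.

Compound 2, `O=C1C=CC[C@@H](/C=C/c2ccc(F)cc2)O1`. In this assay compound 2 gives > 100000 nM, again a limit of the assay.

Compound 3, `O=C1CCC[C@H]([C@@H]2C[C@H]2c2ccccc2)O1`. In this assay compound 3 gives > 100000 nM, also a limit.

The three measured compounds share a lactone core with a side chain carrying a six-membered aromatic ring of carbon only. None of them reached a measurable concentration in this assay; all three sit at the same limit, as the summary the limit of > 100000 nM in this assay, at which 3 of the 3 values shown sit, shows. Compound 2 therefore stands nowhere in particular relative to the others: its value is a limit, and so are the two others, so no order among them can be read.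

The next compound, compound 4, `O=C1C=CC[C@@H](/C=C/c2ccc([N+](=O)[O-])cc2)O1`, is compound 2 with one change: nitro in place of fluoro on an aromatic carbon. Among the compounds with values here, with no measured step of this kind available, and with every measured value resting at the limit, the expected step from compound 2 to compound 4 is none beyond the scatter, so that a number no higher from compound 2 to compound 4 (the limit leaves the size open) is the expectation. For compound 4 the estimated value in this assay is 100000 nM, with a range from 30000 nM to 300000 nM.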

Compound 4, half-maximal inhibitory concentration: > 100000 nM
Compound 4: no number, only a limit; the forecaster's own chance of this, stated with the estimate: 80%; the middle value lies on the limit itself.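

In this assay compound 4 gives > 100000 nM as a limit of the assay, not a number. Within the data shown here, compound 2 rests at that same limit, so no step between compound 2 and compound 4 can be read: the limit of > 100000 nM in this assay, at which 4 of the 4 values shown sit.

The compounds shown leave open what change to the shared core or side chain, if any, would bring a measurable value.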